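The source may report more compounds than this note shows. Statements on the series, on what has been measured and on what is new or still open speak of the compounds shown alone.

Compound 1 `ClCc1ccccc1Cn1cnc2c(Cl)nc(Cl)nc21` gives in a functional assay on NCI-H460 cells (Homo sapiens) for cytotoxicity, read by sulforhodamine B assay, with a stated time of 48 h (a higher number here means that more compound is tolerated, a lower number that less compound is tolerated), the value > 100000 nM, which is a limit of the assay and not a number.
Compound 2 `ClCc1ccccc1Cn1cnc2c(Cl)ncnc21` gives in this assay > 100000 nM, again only a limit.
Compound 3 `ClCc1ccccc1Cn1cnc2ncnc(Cl)c21` gives in this assay > 100000 nM, also a limit.

Compound 2 thus stands where all three measured values sit: the limit of > 100000 nM in this assay, at which 3 of the 3 values shown sit. Nothing in the numbers sets compound 2 apart from the other two, and only a limit is known for it. For the measured compounds named here, the single step among the measured compounds that changes one place, hydrogen in place of chloro on an aromatic carbon, is a step that the two limits leave unreadable from compound 1 to compound 2, unreadable in size because both ends are limits.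

Compound 4 `Nc1nc(Cl)c2ncn(Cc3ccccc3CCl)c2n1` is reached from compound 2 by amino in place of hydrogen on an aromatic carbon. No measured step bears readably on this change; the only recorded step offers no size at all, and the other pairs share no single-point difference. The evidence therefore gives no ground to expect any movement in this assay beyond the scatter, in either direction, and the most likely outcome for compound 4 is a further limit. Compound 4 is accordingly estimated at 100000 nM, with a range from 30000 nM to 300000 nM. The expected step this implies is a number no higher from compound 2 to compound 4 (the limit leaves the size open), which means none that could be read.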

Compound 4, concentration lethal to 50% of the cells: > 100000 nM
Compound 4: a limit, no number; the forecaster's own chance of this, stated with the estimate: 80%; the middle value lies on the limit itself.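

In this assay compound 4 gives > 100000 nM, again a limit of the assay and not a number. The steps to compound 4 from compound 1 and from compound 2 have limits at both ends, and neither can be read in size. The compounds shown leave open what change, if any, would bring a readable value in this assay.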